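A few compounds are considered here, and "the series" means these few. Any claim that something is new, unique, unknown or untested is made for them only; others in the source may bear on it.

In an in vitro ADME assay on microsomes from liver (Mus musculus) for pharmacokinetics, read by LC-MS, with a stated time of 10 min, tested at 1 uM (on this read-out higher numbers stand for fast clearance and lower numbers for slow clearance), compound 1 (`CN1C[C@H](C(=O)Nc2ccc(F)c(F)c2)[C@@H](c2ccc(/C=C/C(=O)Nc3ccccc3N)cc2)C1`) gives 46 mL/min/kg and compound 2 (`CN1C[C@H](C(=O)Nc2ccc(F)cc2F)[C@@H](c2ccc(/C=C/C(=O)Nc3ccccc3N)cc2)C1`) gives 27 mL/min/kg, so these two values sit within the usual scatter of each other. Compound 3 (`CC(C)NC(=O)[C@H]1CN(C)C[C@@H]1c1ccc(/C=C/C(=O)Nc2ccccc2N)cc1`) is still unmeasured. It differs from compound 2 as follows: isopropyl in place of 2,4-difluorophenyl on an amide-type nitrogen. Among the compounds with values here, the only measured step, a 1.7-fold lower number from compound 1 to compound 2 (0.23 log units; within the scatter), swaps one difluorophenyl for another and never removes the ring, so it offers only a weak guide. No change beyond the scatter is therefore expected in this assay. The expected step is a 1.1-fold lower number from compound 2 to compound 3 (0.03 log units; within the scatter). The estimate for compound 3 is 25 mL/min/kg, with an expected range of 10 mL/min/kg to 60 mL/min/kg.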

Compound 3, clearance: 12 mL/min/kg
For compound 3 the middle estimate is 2.1-fold (0.32 log units) above the measured one; low and high end bracket the measured number.
By their numbers in this assay, from the lowest: compound 3; then compounds 2 and 1 (each within the scatter of the next).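

In this assay, swapping one difluorophenyl for another gave no step beyond the scatter, but replacing the ring with isopropyl on the amide-type nitrogen gives a 2.3-fold lower number from compound 2 to compound 3 (0.35 log units; beyond the scatter) and a 3.8-fold lower number from compound 1 to compound 3 (0.58 log units; beyond the scatter). This position can therefore move the clearance number beyond the scatter, and a low number here does not require an aromatic ring. No measurement shown here explains the drop.

Still open, from the compounds shown here alone, is whether other groups at this nitrogen, such as cyclopropyl, a longer chain like n-butyl, or unsubstituted phenyl, would give similarly low numbers.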